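The source may hold more compounds than are shown below. What is called first, only, known or untested is meant among the compounds shown, and "the series" means these compounds.

Compound 1: `COc1cc(N)c(Cl)cc1C(=O)NC1CCNCC1`, 1580 nM in an assay on HEK293 cells for displacement of a labelled ligand from 5-hydroxytryptamine receptor 4 (Homo sapiens), read by scintillation counting; a lower number here means a stronger inhibitor, a higher number a weaker inhibitor.
Compound 2: `COc1cc(N)c(Cl)cc1C(=O)NC1CCN(CCCCCO)CC1`, 63.1 nM.

Of these two numbers, compound 2 holds the lower one, and the gap to compound 1 lies well beyond the usual scatter. For the measured compounds named here, the single step recorded, a 25-fold lower number from compound 1 to compound 2 (1.40 log units; beyond the scatter), came with 5-hydroxypentyl in place of hydrogen on an amine nitrogen in a ring.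

Compound 3, `COc1cc(N)c(Cl)cc1C(=O)NC1CCN(CCN2CCCCC2)CC1`, has not yet been measured. It differs from compound 2 by piperidin-1-yl in place of 3-hydroxypropyl on a saturated chain carbon, two bonds along the chain from an amine nitrogen in a ring. Going by the values given here, the one measured step concerns the presence of the chain on the ring nitrogen, not what sits at its far end, so it gives only indirect guidance: the chain that carried the large gain is kept, and only its tail is exchanged. Compound 3 is therefore expected to land close to compound 2, with a step of a 1.6-fold lower number from compound 2 to compound 3 (0.20 log units; within the scatter). The estimate for compound 3 is 40 nM, between 10 nM and 160 nM.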

Compound 3, inhibition constant: 251 nM
Compound 3: middle estimate off by 6.3-fold (0.80 log units), on the low side, and the stated range ends below it.
By their numbers in this assay, from the lowest: compound 2; then compound 3; then compound 1.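

In this assay, the far end of the chain on the ring nitrogen matters, not only the presence of a chain: a 4.0-fold higher number from compound 2 to compound 3 (0.60 log units; beyond the scatter) came with piperidin-1-yl in place of 3-hydroxypropyl. A substituent on that nitrogen still does better than hydrogen, with a 6.3-fold lower number from compound 1 to compound 3 (0.80 log units; beyond the scatter) for 2-(piperidin-1-yl)ethyl, although that gain is smaller than a 25-fold lower number from compound 1 to compound 2 (1.40 log units; beyond the scatter) for 5-hydroxypentyl. Nothing available explains why the two substituents differ.

5-Hydroxypentyl and 2-(piperidin-1-yl)ethyl differ in both their end group and the chain that carries it, so the compounds shown cannot separate those two changes. A 2-hydroxyethyl group or a longer chain ending in piperidine on the same nitrogen would address that question.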